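The compounds below may be only part of what the source reports. "The series", "measured", "known", "first", "only" and "open" are said of these compounds alone.

Measured compounds:
compound 1 `CC1CCC(Nc2nc(C(F)(F)F)ccc2CNC(=O)C(C)c2ccc(NS(C)(=O)=O)c(F)c2)CC1` — 1130 nM in a functional assay on CHO-K1 cells for antagonist activity at transient receptor potential cation channel subfamily V member 1 (Homo sapiens), read by FLIPR; on this read-out lower numbers stand for stronger inhibition and higher numbers for weaker inhibition
compound 2 `CC(C(=O)NCc1ccc(C(F)(F)F)nc1N1CC=CCC1)c1ccc(NS(C)(=O)=O)c(F)c1` — 12.1 nM in this assay

Of these two numbers, compound 1 stands at the highest, its nearest neighbour being compound 2 at a 93-fold lower number from compound 1 to compound 2 (1.97 log units; beyond the scatter). Compound 3 `CC(C(=O)NCc1ccc(C(F)(F)F)nc1N1CCCCCC1)c1ccc(NS(C)(=O)=O)c(F)c1` differs from compound 1 by azepan-1-yl in place of (4-methylcyclohexyl)amino on an aromatic carbon. Among the compounds with values here, the one step that bears on this change is the one from compound 1 to compound 2, in which a ring amine attached directly to the aromatic carbon took the place of the (4-methylcyclohexyl)amino group and the number fell sharply: a 93-fold lower number from compound 1 to compound 2 (1.97 log units; beyond the scatter). On these data alone, compound 3 carries the same kind of replacement, a ring nitrogen bonded straight to the aromatic carbon, so a large step downward is expected in this assay, though the seven-membered ring is untested and the size of the step is uncertain. Compound 3 is therefore estimated at 25 nM (range 6 nM to 120 nM), an expected step of a 45-fold lower number from compound 1 to compound 3 (1.66 log units; beyond the scatter).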

Compound 3, half-maximal inhibitory concentration: 25.1 nM
The estimate for compound 3 lay 1.0-fold (0.00 log units) below the measured number; low and high end bracket the measured number.
By their numbers in this assay, from the lowest: compound 2; then compound 3; then compound 1.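

In this assay, within the data shown here, the step of a 45-fold lower number from compound 1 to compound 3 (1.65 log units; beyond the scatter) shows that the large fall at this aromatic carbon is not tied to the one ring in compound 2: azepan-1-yl, which carries no hydrogen-bond donor, also gives a number far below that of (4-methylcyclohexyl)amino, which carries one. The step of a 2.1-fold higher number from compound 2 to compound 3 (0.32 log units; beyond the scatter) is modest, though beyond the scatter, so the change of ring between these two compounds moves the number far less than leaving the (4-methylcyclohexyl)amino group does. Nothing available explains either step.

The compounds shown do not separate the effect of the ring from that of losing the hydrogen-bond donor. They also leave open how an open-chain diethylamino group or a morpholine ring would behave on this aromatic carbon.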